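The source may hold more compounds than are shown below. What is called first, only, known or untested is meant among the compounds shown, and "the series" means these compounds.

Working notes on the series. In an assay on isolated protein for inhibition of DNA topoisomerase 1 (Homo sapiens), with a stated time of 15 min, tested at 200 uM (a higher number here means more inhibition at the concentration tested (going by the name of the read-out), a lower number less inhibition), compound 3 `CNCCNc1c(F)cc2c(=O)c(C(=O)O)cn(Cc3ccc(-c4ccccc4)cc3)c2c1OC` gives 10%. Compound 1 `COc1c(N2CC[C@@H](CO)C2)c(F)cc2c(=O)c(C(=O)O)cn(Cc3ccc(-c4ccccc4)cc3)c12` gives 10% in this assay, and compound 2 `CNCCNc1cc2c(cc1F)c(=O)c(C(=O)O)cn2Cc1ccc(-c2ccccc2)cc1` gives 10%, so compound 3 stands level with both at the digits shown. The two steps into compound 3 read no change at the digits printed from compound 1 to compound 3 (within the scatter) and no change at the digits printed from compound 2 to compound 3 (within the scatter). Compound 4 `COc1c(NCCN)c(F)cc2c(=O)c(C(=O)O)cn(Cc3ccc(-c4ccccc4)cc3)c12` differs from compound 3 by hydrogen in place of methyl on an amine nitrogen. For the measured compounds named here, neither measured step touches the amine nitrogen, so no step bears directly on this change; the series as a whole sits flat in this assay. The expected step is therefore none beyond the scatter, no change at the digits printed from compound 3 to compound 4 (within the scatter). Compound 4 is estimated at 10%, with a range from 0% to 25%.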

Compound 4, a percentage reported as inhibition, at one concentration (the size of the read-out at that concentration, not a potency): 10%
For compound 4 middle estimate and measured number coincide at the digits printed, within the range that was stated.
By their numbers in this assay, from the lowest: compounds 1, 2, 3 and 4 (each within the scatter of the next).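

Hydrogen in place of methyl on the amine nitrogen gives (no change at the digits printed from compound 3 to compound 4 (within the scatter)) in this assay, the first reading at this nitrogen, so the methyl shows no effect on the read-out here. The (2-aminoethyl)amino group in place of 3-(hydroxymethyl)pyrrolidin-1-yl likewise gives (no change at the digits printed from compound 1 to compound 4 (within the scatter)) . Nothing available explains this flat result. On these data alone, whether a dimethylamino end group or a longer chain such as 3-aminopropyl on the same amine would move the read-out remains open, as does the role of the carboxylic acid, which all four compounds share.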